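The source may hold more compounds than are shown below. What is called first, only, known or untested is meant among the compounds shown, and "the series" means these compounds.

Measured so far in a functional assay on A549 cells (Homo sapiens) for antiproliferative activity, read by MTT assay, with a stated time of 72 h (a higher number here means a weaker inhibitor, a lower number a stronger inhibitor), as follows
- compound 1 `COc1cccc(N2C(=O)COc3ccc(-c4cnc(Cl)c(NS(=O)(=O)c5ccc(F)cc5)c4)cc32)c1` gives 32700 nM in this assay
- compound 2 `O=C1COc2ccc(-c3cnc(Cl)c(NS(=O)(=O)c4ccc(F)cc4)c3)cc2N1C1CCCCC1` gives 37900 nM in this assay
- compound 3 `COc1ccc(N2C(=O)COc3ccc(-c4cnc(Cl)c(NS(=O)(=O)c5ccc(F)cc5)c4)cc32)cc1` gives 30400 nM in this assay

The steps of a 1.2-fold higher number from compound 1 to compound 2 (0.06 log units; within the scatter) and a 1.1-fold lower number from compound 1 to compound 3 (0.03 log units; within the scatter) are both within the scatter, so compound 1 stands level with the other two, and a 1.2-fold lower number from compound 2 to compound 3 (0.10 log units; within the scatter) is no larger a matter.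

Compound 4 `COc1cccc(N2C(=O)COc3ccc(-c4cnc(OC)c(NS(=O)(=O)c5ccc(F)cc5)c4)cc32)c1` keeps the core of compound 1 and changes one group, methoxy in place of chloro on an aromatic carbon, next to the ring nitrogen: methoxy in place of chloro on an aromatic carbon (para to a large group).

All three measured steps sit on the amide-type nitrogen in a ring. None touches the chloro place, so they bear on this change only indirectly. Going by the values given here, the data hold no direct step for it, and no step beyond the scatter is expected in this assay on this evidence. From the compounds shown here alone, the direction stays open, with a slightly lower number as a weak guess.

The expected step is a 1.3-fold lower number from compound 1 to compound 4 (0.12 log units; within the scatter), an estimate only. For compound 4 the estimated value is 25000 nM, with 7000 nM to 60000 nM as the expected range.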

Compound 4, half-maximal inhibitory concentration: 11200 nM
The estimate for compound 4 lay 2.2-fold (0.35 log units) above the measured number; the measured number falls inside the stated range.
By their numbers in this assay, from the lowest: compound 4; then compounds 3, 1 and 2 (each within the scatter of the next).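

In this assay, the aromatic carbon next to the ring nitrogen is a place where the number moves: methoxy in place of chloro gives a 2.9-fold lower number from compound 1 to compound 4 (0.47 log units; beyond the scatter) and so lies beyond the scatter, whereas the changes on the amide-type nitrogen in a ring all stayed within it. Going by these compounds alone, this is the first sign that a change away from that nitrogen can shift the antiproliferative read-out. The step is modest and rests on one pair, so it marks this place as sensitive and sets no trend. No evidence at hand explains the step.

From the compounds shown here alone, whether the shift is particular to methoxy remains open, as an amine, a hydroxy group or a longer chain such as ethoxy at this carbon would test that. Also open, going by these compounds, is whether methoxy gives a similar step with the cyclohexyl of compound 2 or the 4-methoxyphenyl of compound 3 on the ring nitrogen.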